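Cyclopropyl in Place of 4-Fluorophenyl at the Shared Core

The compounds below may be only part of what the source reports. "The series", "measured", "known", "first", "only" and "open" are said of these compounds alone.

Compound 1 `CCOC(=O)c1cnc(C(C)(C)C)nc1NN1C(=O)C=C(C)C1=O`: 1000 nM
Compound 2 `CCOC(=O)c1cnc(-c2ccc(F)cc2)nc1NN1C(=O)C=C(C)C1=O`: 700 nM

Going by the values given here, in a functional assay on Jurkat cells for inhibition of nuclear factor NF-kappa-B complex (Homo sapiens) (a higher number here means a weaker inhibitor, a lower number a stronger inhibitor), compound 2 gives the lowest of the two numbers so far, while compound 1 sits nearby with a 1.4-fold lower number from compound 1 to compound 2 (0.15 log units; within the scatter). Compound 3 `CCOC(=O)c1cnc(C2CC2)nc1NN1C(=O)C=C(C)C1=O` carries the change (cyclopropyl in place of 4-fluorophenyl on an aromatic carbon). Among the compounds with values here, the only step seen, from tert-butyl to 4-fluorophenyl, was within the scatter, so no guidance beyond the scatter exists for a cyclopropyl group; the number for compound 3 in this assay is therefore expected near those of compounds 1 and 2. Compound 3 is estimated at 1000 nM, range 400 nM to 2500 nM, a step of a 1.4-fold higher number from compound 2 to compound 3 (0.15 log units; within the scatter) that is expected.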

Compound 3, half-maximal inhibitory concentration: 1000 nM
Beside the measured number, compound 3's estimate shows no gap at the digits printed; the measured number falls inside the stated range.
By their numbers in this assay, from the lowest: compounds 2, 1 and 3 (each within the scatter of the next).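

At this position, between two ring nitrogen atoms, the change to cyclopropyl gives a 1.4-fold higher number from compound 2 to compound 3 (0.15 log units; within the scatter) and no change at the digits printed from compound 1 to compound 3 (within the scatter) in this assay. A non-aromatic ring of 3 heavy atoms thus reads alike with 4-fluorophenyl and tert-butyl, so all three groups at this position lie within the scatter of one another. Nothing measured here accounts for this. On these data alone, whether an amine or a carboxylic acid at this position would shift the number beyond the scatter stays open, as does whether any group here can do so.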